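The compounds below may be only part of what the source reports. "The series", "measured", "known", "first", "only" and "open" are said of these compounds alone.

Of the compounds shown here, two on the shared core have been measured. In a functional assay on DLD-1 cells (Homo sapiens) for inhibition, read by luminescence, with a stated time of 3 days (a lower number here means a stronger inhibitor of growth, a higher number a weaker inhibitor of growth), compound 1 `CC[C@@H]1CC[C@@H](C(=O)N2CCOCC2)N1C(=O)C1=C(C(C)C)N2C(=N[C@@](C)(c3ccc(Cl)cc3)[C@H]2c2ccc(Cl)cc2)S1` gives 4200 nM and compound 2 `CC(C)C1=C(C(=O)N2[C@H](C)CC[C@H]2C(=O)N2CCN(C)C(C)(C)C2)SC2=N[C@@](C)(c3ccc(Cl)cc3)[C@@H](c3ccc(Cl)cc3)N21` gives 6300 nM, so the two values lie within the usual scatter of each other and compound 1 stands level with compound 2. Compound 3 `CC[C@@H]1CC[C@@H](C(=O)N2CCN(C(C)=O)[C@H](C)C2)N1C(=O)C1=C(C(C)C)N2C(=N[C@@](C)(c3ccc(Cl)cc3)[C@H]2c2ccc(Cl)cc2)S1` is derived from compound 1 by one change on a carbonyl carbon: a group of 10 heavy atoms (7 carbon, 2 nitrogen, 1 oxygen; one six-membered non-aromatic ring with 2 hetero atoms) in place of a group of 6 heavy atoms (4 carbon, 1 nitrogen, 1 oxygen; one six-membered non-aromatic ring with 2 hetero atoms), on a carbonyl carbon. For the measured compounds named here, no measured pair differs in only one place, so the data give no direct size for such a change. Compound 2, which carries a group other than morpholin-4-yl on that carbonyl carbon, reads 6300 nM, and on this thin evidence no step beyond the scatter is expected in this assay. The estimated step is a 1.1-fold higher number from compound 1 to compound 3 (0.03 log units; within the scatter). For compound 3 the expected concentration for growth inhibition is 4500 nM, with an estimated range of 2000 nM to 10000 nM.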

Compound 3, concentration for 50% growth inhibition: 10000 nM
The estimate for compound 3 lay 2.2-fold (0.35 log units) below the measured number; low and high end bracket the measured number.
By their numbers in this assay, from the lowest: compounds 1, 2 and 3 (each within the scatter of the next, the first and the last beyond it).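

For the compounds shown here, this is the first comparison on the shared core that differs in only one place. In this assay, placing the ring of 10 heavy atoms on the carbonyl carbon instead of morpholin-4-yl gives a 2.4-fold higher number from compound 1 to compound 3 (0.38 log units; beyond the scatter), so this position is not indifferent to the group it carries, although the step is modest and points towards weaker growth inhibition. No measurement available here explains this step.

The compounds shown do not separate the contribution of the ring's methyl substituent from that of its acetyl group, and the single step cannot show which of them matters. As far as these compounds go, it also remains open whether an open-chain amine such as dimethylamino on that carbonyl carbon would give a lower or a higher number than morpholin-4-yl.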